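The source may report more compounds than this note shows. Statements on the series, on what has been measured and on what is new or still open speak of the compounds shown alone.

The series rests on a shared core, seen in compound 1 `COc1ccc(-c2nc(C)c(C(=O)CSc3nc(-c4ccc(OC)cc4)c(C#N)c(=O)[nH]3)s2)cc1`, which in a functional assay on U-87MG ATCC cells for antiproliferative activity against U-87 MG (Homo sapiens), read by MTT assay, with a stated time of 48 h, tested at 100 uM (on this read-out lower numbers stand for a stronger effect and higher numbers for a weaker effect at the one concentration tested), gives 11.5%. Compound 2 `COc1ccc(-c2nc(C)c(C(=O)CSc3nc(-c4cccc(OC)c4)c(C#N)c(=O)[nH]3)s2)cc1` carries the same core and in this assay gives 12.4%, the second highest of the three numbers available. Its nearest neighbour is compound 1, and the step of a number 0.9 percentage points higher from compound 1 to compound 2 (within the scatter) is within the scatter. Compound 3 `COc1cccc(-c2nc(SCC(=O)c3sc(-c4ccccc4)nc3C)[nH]c(=O)c2C#N)c1` gives 21.8% in this assay, and the step of a number 9.4 percentage points higher from compound 2 to compound 3 (within the scatter) is likewise within the scatter.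

The unmeasured compound 4 `COc1ccc(-c2nc(C)c(C(=O)CSc3nc(-c4ccccc4)c(C#N)c(=O)[nH]3)s2)cc1` differs from compound 2 in one place: hydrogen in place of methoxy on an aromatic carbon. The step from compound 2 to compound 3 is the same kind of change, hydrogen in place of methoxy on an aromatic carbon, though at another place in the molecule, and it amounted to a number 9.4 percentage points higher from compound 2 to compound 3 (within the scatter), within the scatter. The step from compound 1 to compound 2, a methoxy relocated on its ring, was also within the scatter at a number 0.9 percentage points higher from compound 1 to compound 2 (within the scatter). Neither step points to a shift beyond the scatter.

Compound 4 is therefore expected to give about 16% in this assay, within a range of 6% to 28%. The expected step is a number 3.6 percentage points higher from compound 2 to compound 4 (within the scatter), a change no larger than the scatter.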

Compound 4, a percentage reported as activity, at one concentration (the size of the read-out at that concentration, not a potency): 10.9%
For compound 4 the middle estimate is 5.1 percentage points above the measured one; low and high end bracket the measured number.
By their numbers in this assay, from the lowest: compounds 4, 1, 2 and 3 (each within the scatter of the next, the first and the last beyond it).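

In this assay, hydrogen in place of the methoxy, meta to a large group, gives a number 1.5 percentage points lower from compound 2 to compound 4 (within the scatter), and the same exchange on the core of compound 1 gives a number 0.6 percentage points lower from compound 1 to compound 4 (within the scatter). The earlier compounds showed only that the methoxy could be relocated on this ring without a step beyond the scatter; compound 4 adds that losing it altogether, the change from 3-methoxyphenyl to phenyl, also leaves the read-out within the scatter of both methoxy compounds, so at the one concentration tested neither methoxy is shown to be needed here. The change also cannot be told apart between the two places in the molecule where it has been read: the same change on two cores in this assay, a number 9.4 percentage points higher (within the scatter) from compound 2 to compound 3 and a number 0.6 percentage points lower (within the scatter) from compound 1 to compound 4, 10 percentage points apart, within the scatter of two such steps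

From the compounds shown here alone, what remains open is whether a different group at this position, such as an amine, a carboxylic acid or a longer alkoxy chain, would move the number beyond the scatter. Also open, going by these compounds, is whether hydrogen in place of methoxy at both places in one molecule would do so, and a single-concentration read-out says nothing about potency.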